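Chloro-bearing carboxyphenyl ether in compound 4

A few compounds are considered here, and "the series" means these few. Any claim that something is new, unique, unknown or untested is made for them only; others in the source may bear on it.

Compound 3 `Cc1c(OCCCCOc2cccc(C(=O)O)c2)ccc(C(=O)CC(C)C)c1O` gives 1430 nM in an assay on HEK293 cells for positive allosteric modulation of metabotropic glutamate receptor 3 (Rattus norvegicus), read by thallium flux, with a stated time of 2.5 min (a lower number here means that less compound is needed, a higher number that more compound is needed for the effect), which puts it second highest of the three measured numbers; its nearest neighbour is compound 2 `Cc1c(OCCCCOc2ccc(C(=O)O)cc2Cl)ccc(C(=O)CC(C)C)c1O` with 1140 nM, and its furthest is compound 1 `Cc1c(OCCCCOc2ccc(C(=O)O)cc2)ccc(C(=O)CC(C)C)c1O` with 2720 nM. Both gaps lie within the scatter of the assay. Compound 4 `Cc1c(OCCCCOc2ccc(C(=O)O)c(Cl)c2)ccc(C(=O)CC(C)C)c1O` differs from compound 3 in one place: 4-carboxy-3-chlorophenyl in place of 3-carboxyphenyl on an oxygen on a saturated carbon. Among the compounds with values here, two measured steps bear on this. The step of a 1.9-fold lower number from compound 1 to compound 3 (0.28 log units; within the scatter) shows that shifting the carboxy group on the phenyl ether did not move the number beyond the scatter. The step of a 2.4-fold lower number from compound 1 to compound 2 (0.38 log units; beyond the scatter), a chloro in place of hydrogen on the same phenyl, gave a modest lowering beyond the scatter. The step of a 1.3-fold higher number from compound 2 to compound 3 (0.10 log units; within the scatter) again stayed within the scatter. Compound 4 carries a chloro on a 4-carboxyphenyl much as compound 2 does, so a modest lowering is expected in this assay, namely a 1.4-fold lower number from compound 3 to compound 4 (0.16 log units; within the scatter). Compound 4 is therefore estimated at 1000 nM, with a range from 400 nM to 2500 nM.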

Compound 4, half-maximal effective concentration: 2050 nM
The estimate for compound 4 lay 2.1-fold (0.31 log units) below the measured number; the measured number falls inside the stated range.
By their numbers in this assay, from the lowest: compounds 2, 3, 4 and 1 (each within the scatter of the next, the first and the last beyond it).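

In this assay, the 4-carboxy-3-chlorophenyl group on this oxygen does not separate from the groups before it: a 1.4-fold higher number from compound 3 to compound 4 (0.16 log units; within the scatter), a 1.8-fold higher number from compound 2 to compound 4 (0.25 log units; within the scatter) and a 1.3-fold lower number from compound 1 to compound 4 (0.12 log units; within the scatter) all lie within the scatter. The earlier chloro step, a 2.4-fold lower number from compound 1 to compound 2 (0.38 log units; beyond the scatter), lay beyond the scatter, and the chloro of 4-carboxy-3-chlorophenyl does not repeat that result, so among these compounds a chloro on the carboxyphenyl does not give a step beyond the scatter in every case. Nothing available explains this result.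

On these data alone, it remains open whether a methyl or a nitrile in place of this chloro would give a step beyond the scatter. As far as these compounds go, it is also open how an amide or a tetrazole in place of the carboxylic acid would compare.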